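Replacing the aryl amide of compound 2 with propoxymethyl

The compounds below may be only part of what the source reports. "The series", "measured", "known", "first", "only" and "open" are said of these compounds alone.

Compound 2 `CCN(CC)c1cc2[nH]c(C3CCCCC3)nc2cc1NC(=O)c1ccc(OC(F)F)cc1` is the starting point, and it has been tested in an ADME assay on Vero cells (Chlorocebus sabaeus) for cytotoxicity, read by resazurin assay, with a stated time of 3 days; a lower number here means a stronger inhibitor, a higher number a weaker inhibitor. In this assay compound 2 gives > 100 ug/mL, which is a limit of the assay rather than a measured number. Compound 3 `CN(C)c1cc2[nH]c(C3CCCCC3)nc2cc1NC(=O)c1ccc(OC(F)F)cc1` differs from compound 2 only by a dimethylamino in place of diethylamino on an aromatic carbon. In this assay compound 3 gives > 100 ug/mL, again a limit. Compound 1 `CCCCOC(=O)Nc1cc2nc(C3CCCCC3)[nH]c2cc1N(CC)CCN(CC)CC` differs from both in more than one place. In this assay compound 1 gives > 50 ug/mL, also a limit. Going by the values given here, because every value sits at the limit of > 100 ug/mL in this assay, at which 2 of the 3 values shown sit, or at the limit of > 50 ug/mL in this assay, at which 1 of the 3 values shown sits, the only single-point step, a step that the two limits leave unreadable from compound 2 to compound 3, cannot be read, and no measured step gives a size or direction to carry forward.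

Compound 4 `CCCOCC(=O)Nc1cc2nc(C3CCCCC3)[nH]c2cc1N(CC)CC` is the next compound, differing from compound 2 by propoxymethyl in place of 4-(difluoromethoxy)phenyl on a carbonyl carbon. With nothing readable among the measured steps, the expected step that the limit leaves unreadable from compound 2 to compound 4 is no change beyond the scatter, and compound 4 is expected to remain at a limit of this assay. The estimate for compound 4 is 120 ug/mL, within a range of 40 ug/mL to 300 ug/mL.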

Compound 4, half-maximal inhibitory concentration: > 100 ug/mL
Compound 4 ended at the assay's limit; the forecaster's own chance of this, stated with the estimate: 80%; the middle value lies beyond the limit too.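

In this assay compound 4 gives > 100 ug/mL, which is a limit of the assay and not a number. The step from compound 2 to compound 4 cannot be read, because both compounds sit at the same limit: the limit of > 100 ug/mL in this assay, at which 3 of the 4 values shown sit.

The compounds shown leave open at what concentration any of them would harm these cells, and whether propoxymethyl in place of 4-(difluoromethoxy)phenyl changes that concentration at all.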